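A few compounds are considered here, and "the series" means these few. Any claim that something is new, unique, unknown or untested is made for them only; others in the source may bear on it.

Working notes on the series, read in an ADME assay on J774.A1 cells (Mus musculus) for cytotoxicity, read by MTT assay; a higher number here means that more compound is tolerated, a lower number that less compound is tolerated. Compound 1 (`O[C@H]1CCc2ccccc2[C@@H]1n1ccnc1`) gives > 100 ug/mL, which is a limit of the assay and not a number. Compound 2 (`FC(F)(F)c1ccc(O[C@H]2CCc3ccccc3[C@@H]2n2ccnc2)cc1`) gives 52.5 ug/mL. Compound 3 (`O=[N+]([O-])c1ccc(O[C@H]2CCc3ccccc3[C@@H]2n2ccnc2)cc1`) gives 21.4 ug/mL, the lower of the two actual numbers. Compound 4 (`O=[N+]([O-])c1ccc(O[C@H]2CCc3ccccc3[C@@H]2n2ccnc2)c(F)c1`) differs from compound 3 as follows: fluoro in place of hydrogen on an aromatic carbon. This is fluoro in place of hydrogen on an aromatic carbon, ortho to a large group and meta to a nitro group. For the measured compounds named here, no measured step covers this change. The nearest guide is a 2.5-fold lower number from compound 2 to compound 3 (0.39 log units; beyond the scatter), a modest step that swaps a larger group at another place, so no step beyond the scatter is expected in this assay, and no direction is favoured. The expected step is a 1.1-fold lower number from compound 3 to compound 4 (0.03 log units; within the scatter). Compound 4 is estimated at 20 ug/mL, with an expected range of 10 ug/mL to 40 ug/mL.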

Compound 4, half-maximal cytotoxic concentration: 32.1 ug/mL
Compound 4: the middle estimate sits 1.6-fold (0.21 log units) below what was measured; low and high end bracket the measured number.
By their numbers in this assay, from the lowest: compounds 3, 4 and 2 (each within the scatter of the next, the first and the last beyond it). At a limit, above all of these: compound 1.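

In this assay, for the compounds shown here, fluoro in place of hydrogen on an aromatic carbon, ortho to a large group and meta to a nitro group, gives a 1.5-fold higher number from compound 3 to compound 4 (0.18 log units; within the scatter) and so produces no step that can be read as a change. With the nitro group present in both compounds, this step isolates the fluoro at this one position. No measurement shown gives a cause for this step.

As far as these compounds go, whether a methoxy group or an amine at the same position would also stay within the scatter remains open. Also open, from the compounds shown here alone, is whether fluoro would behave the same way alongside the trifluoromethyl group of compound 2.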